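Swapping the Side Chain of Compound 3

This account rests on a few compounds, and the source may have more. Where it says the series, first, only, none or still open, it means among the compounds named here.

In a functional assay on ECa-109 cells (Homo sapiens) for antiproliferative activity, read by MTT assay, with a stated time of 48 h (a lower number here means a stronger inhibitor, a higher number a weaker inhibitor), compound 3 (`CN(C)CCCn1nc(C2=C(c3cn(C)c4ccccc34)C(=O)NC2=O)c2cccnc21`) gives > 100000 nM, which is a limit of the assay and not a number. Compound 1 (`Cn1cc(C2=C(c3nn(CCCn4cccc4)c4ncccc34)C(=O)NC2=O)c2ccccc21`) gives > 100000 nM, also a limit. Only compound 2 (`CN(C)CCCn1nc(C2=C(c3cn(C)c4ccccc34)C(=O)N(c3ccccc3)C2=O)c2cccnc21`) gives a true number, 5840 nM.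

Compound 4 (`Cn1cc(C2=C(c3nn(CCCCn4ccnc4)c4ncccc34)C(=O)NC2=O)c2ccccc21`) differs from compound 3 in one place: (1H-imidazol-1-yl)methyl in place of dimethylamino on a saturated chain carbon, three bonds along the chain from an aromatic nitrogen. Cut one bond further out, this is 3-(dimethylamino)propyl to 4-(1H-imidazol-1-yl)butyl.

The closest comparison on this chain is a step that the two limits leave unreadable from compound 1 to compound 3, so it gives no size to carry over. Going by the values given here, the one readable step is an at least 17-fold higher number from compound 2 to compound 3 (1.23 log units; beyond the scatter), with hydrogen in place of phenyl on an amide-type nitrogen in a ring. Compound 4 keeps that hydrogen, and (the limit of > 100000 nM in this assay, at which 2 of the 3 values shown sit). In this assay, no gain beyond the scatter is therefore expected, and a reading at the limit is the likeliest outcome.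

For compound 4 the estimated value is 100000 nM, with an expected range from 30000 nM to 200000 nM. This estimate means an expected a number no higher from compound 3 to compound 4 (the limit leaves the size open).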

Compound 4, half-maximal inhibitory concentration: 23500 nM
Compound 4: the middle estimate sits 4.3-fold (0.63 log units) above what was measured; measured number outside the range, below it.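

In this assay the result is an at least 4.2-fold lower number from compound 3 to compound 4 (0.62 log units; beyond the scatter), and likewise an at least 4.2-fold lower number from compound 1 to compound 4 (0.62 log units; beyond the scatter). With the amide hydrogen kept, a change on the saturated chain alone brings a reading off the limit, which neither the dimethylamino chain nor the 1H-pyrrol-1-yl chain achieved, and the step between those two cannot be read. The other two compounds that keep this hydrogen remain at that limit: the limit of > 100000 nM in this assay, at which 2 of the 4 values shown sit.

The step to 4-(1H-imidazol-1-yl)butyl changes the end group and the chain name together, so the compounds shown do not separate the two, and a 3-(1H-imidazol-1-yl)propyl chain would be needed to do so. Also open, on these data alone, is how a morpholine or a carboxylic acid at the chain end would read, and how this chain would read with phenyl on the amide-type nitrogen.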